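The source may report more compounds than this note shows. Statements on the series, on what has been measured and on what is new or still open speak of the compounds shown alone.

Compound 1 `CN1C(=S)[C@@H](NC(=O)c2nc(Cc3ccccc3)n(CCCF)n2)COc2ccccc21` — 4760 nM
Compound 2 `CN1C(=S)[C@@H](NC(=O)c2nc(Cc3ccccc3)n(C3CCOCC3)n2)COc2ccccc21` — 2260 nM

In a functional assay on HT-29 cells (Homo sapiens) for inhibition, read by luminescence and CellTiter-Glo, with a stated time of 24 h (on this read-out lower numbers stand for an effect already at smaller amounts and higher numbers for an effect only at larger amounts of compound), compound 2 gives the lowest of the two numbers shown, and the only measured step, a 2.1-fold lower number from compound 1 to compound 2 (0.32 log units; beyond the scatter), concerns the same aromatic nitrogen. Compound 3 `Cc1cnc(-n2nc(C(=O)N[C@H]3COc4ccccc4N(C)C3=S)nc2Cc2ccccc2)nc1` changes that position again: 5-methylpyrimidin-2-yl in place of oxan-4-yl on an aromatic nitrogen. For the measured compounds named here, since the one step at this site was only modest, and no measured pair tests an aromatic ring there, a similarly small shift in either direction, or none beyond the scatter, is expected. Compound 3 is estimated at 2000 nM, with a range from 700 nM to 6000 nM, which corresponds to an expected step of a 1.1-fold lower number from compound 2 to compound 3 (0.05 log units; within the scatter).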

Compound 3, half-maximal effective concentration: 1950 nM
Beside the measured number, compound 3's estimate is 1.0-fold (0.01 log units) above it; low and high end bracket the measured number.
By their numbers in this assay, from the lowest: compounds 3 and 2 (each within the scatter of the next); then compound 1.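

In this assay, for the compounds shown here, the step of a 1.2-fold lower number from compound 2 to compound 3 (0.06 log units; within the scatter) shows that this aromatic nitrogen can carry the six-membered aromatic 5-methylpyrimidin-2-yl in place of the non-aromatic oxan-4-yl, a contrast the earlier compounds did not offer. Measured against the 3-fluoropropyl chain, the change gives a 2.4-fold lower number from compound 1 to compound 3 (0.39 log units; beyond the scatter), so both rings now stand apart from that chain in the same direction. Nothing available accounts for these numbers. The compounds shown leave open whether a phenyl ring or a piperidine with its amine at this nitrogen would behave the same way.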